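The compounds below may be only part of what the source reports. "The series", "measured", "known", "first", "only" and "open" are said of these compounds alone.

Of the compounds shown here, two that share one core have been tested for how strongly they curb the growth of a human breast cancer cell line. Compound 1 `O=C1C[C@H](OCc2cn(-c3ccc(Cl)cc3)nn2)[C@H]2CO[C@@H]1O2` carries a 4-chlorophenyl group on an aromatic nitrogen of its five-membered aromatic ring with 3 nitrogen. In a functional assay on MDA-MB-231 cells (Homo sapiens) for cytotoxicity, read by MTT assay, with a stated time of 48 h (on this read-out higher numbers stand for weaker inhibition and lower numbers for stronger inhibition), compound 1 gives 26100 nM. Compound 2 `CCCCn1cc(CO[C@H]2CC(=O)[C@@H]3OC[C@H]2O3)nn1` carries a butyl group at that same nitrogen, and in this assay compound 2 gives 27900 nM. Among the measured compounds shown here, the one measured step, a 1.1-fold higher number from compound 1 to compound 2 (0.03 log units; within the scatter), shows that exchanging the whole aromatic group for a short chain left the read-out essentially unchanged. Compound 1 therefore stands alongside compound 2, the two numbers within the scatter of each other.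

Compound 3 `O=C1C[C@H](OCc2cn(-c3ccccc3Br)nn2)[C@H]2CO[C@@H]1O2` differs from compound 1 by 2-bromophenyl in place of 4-chlorophenyl on an aromatic nitrogen. For the measured compounds named here, only the step from compound 1 to compound 2 bears on this change, and since even that larger exchange stayed within the scatter, a swap of one halogen-bearing phenyl for another is expected to give a 1.0-fold lower number from compound 1 to compound 3 (0.00 log units; within the scatter), no shift beyond the scatter. Compound 3 is accordingly estimated at 26000 nM, with a range from 11000 nM to 60000 nM.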

Compound 3, half-maximal inhibitory concentration: 22500 nM
Compound 3: the middle estimate sits 1.2-fold (0.06 log units) above what was measured, and the stated range covers the measured number.
By their numbers in this assay, from the lowest: compounds 3, 1 and 2 (each within the scatter of the next).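

In this assay the exchange of 4-chlorophenyl for 2-bromophenyl on the aromatic nitrogen gives a 1.2-fold lower number from compound 1 to compound 3 (0.06 log units; within the scatter) and so the two numbers lie within the scatter of each other, even though the halogen and its place on the phenyl ring differ at once. The exchange of butyl for 2-bromophenyl at the same nitrogen gives a 1.2-fold lower number from compound 2 to compound 3 (0.09 log units; within the scatter) and so this second halogen-bearing phenyl also cannot be told apart from the short chain, which means that all three groups at this position now give numbers within the scatter of one another. Nothing measured here offers an explanation for this lack of separation among the three groups.

From the compounds shown here alone, compound 1 and compound 3 differ in both the halogen and its place, so the share of each remains open, and a 4-bromophenyl group at this nitrogen would begin to separate them. Going by these compounds, it also remains open whether a quite different group here, such as an amine or a carboxylic acid on the phenyl ring or a longer chain in place of butyl, would shift the number beyond the scatter.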